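The source may hold more compounds than are shown below. What is called first, only, known or untested is meant among the compounds shown, and "the series" means these compounds.

Series notes. Compound 1 `Nc1ccc(Nc2nc3ccccc3nc2S(=O)(=O)c2ccccc2)cc1` gives 3400 nM in a functional assay on KB cells (Homo sapiens) for cytotoxicity, read by MTT assay, with a stated time of 72 h; a higher number here means a weaker inhibitor, a lower number a stronger inhibitor. Compound 2 `Nc1cccc(Nc2nc3ccccc3nc2S(=O)(=O)c2ccccc2)c1` gives 4290 nM in this assay; the change 3-aminophenyl in place of 4-aminophenyl on a nitrogen on an aromatic ring accounts for a step of a 1.3-fold higher number from compound 1 to compound 2 (0.10 log units; within the scatter). Compound 3 `COc1ccc(S(=O)(=O)c2nc3ccccc3nc2Nc2ccc(N)cc2)cc1` sits on a different core, separated from compound 1 by methoxy in place of hydrogen on an aromatic carbon, a step of a 5.2-fold higher number from compound 1 to compound 3 (0.72 log units; beyond the scatter); in this assay compound 3 gives 17800 nM, the highest of the three numbers. Compound 4 `COc1ccc(S(=O)(=O)c2nc3ccccc3nc2Nc2cccc(N)c2)cc1` has not yet been measured. It differs from compound 3 by 3-aminophenyl in place of 4-aminophenyl on a nitrogen on an aromatic ring, the same change as that between compound 1 and compound 2, with the place described in identical words, now applied on the core of compound 3. The expected step is a 1.2-fold higher number from compound 3 to compound 4 (0.09 log units; within the scatter), which rests on the earlier step of a 1.3-fold higher number from compound 1 to compound 2 (0.10 log units; within the scatter) having stayed within the scatter. Compound 4 is therefore expected to give about 22000 nM, with a range of 11000 nM to 45000 nM.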

Compound 4, half-maximal inhibitory concentration: 4960 nM
Compound 4: the middle estimate sits 4.4-fold (0.65 log units) above what was measured; the whole stated range lies above it.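

In this assay, 3-aminophenyl in place of 4-aminophenyl did not carry over between the two cores, giving a 3.6-fold lower number from compound 3 to compound 4 (0.55 log units; beyond the scatter) on the methoxy-bearing core: the same change on two cores in this assay, a 1.3-fold higher number (0.10 log units; within the scatter) from compound 1 to compound 2 and a 3.6-fold lower number (0.55 log units; beyond the scatter) from compound 3 to compound 4, 4.5-fold (0.66 log units) apart, beyond the scatter of two such steps Methoxy in place of hydrogen also gave a different result with the 3-aminophenyl group, at a 1.2-fold higher number from compound 2 to compound 4 (0.06 log units; within the scatter): the same change on two cores in this assay, a 5.2-fold higher number (0.72 log units; beyond the scatter) from compound 1 to compound 3 and a 1.2-fold higher number (0.06 log units; within the scatter) from compound 2 to compound 4, 4.5-fold (0.66 log units) apart, beyond the scatter of two such steps Across these four compounds, the effect of either change therefore depends on the other, but this rests on a single set of two cores and does not show the cause or whether the dependence extends to other cores.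

From the compounds shown here alone, whether it persists with a chlorine or a hydroxyl in place of methoxy, or an acetamide in place of the amine, remains open.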